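This account rests on a few compounds, and the source may have more. Where it says the series, first, only, none or still open, it means among the compounds named here.

Of the compounds shown here, three sharing one core have been measured in an ADME assay on cells (Homo sapiens) for cytotoxicity, read by polymerase chain reaction, with a stated time of 3 days; a lower number here means that less compound is tolerated, a higher number that more compound is tolerated. Compound 1 `Cc1nc(N)nc(N[C@@H]2C[C@H](CO)[C@@H](O)[C@H]2O)c1-c1nc2ccccc2s1` gives 4000 nM in this assay. Compound 2 `CCOC(=O)NCCNc1nc(C)c(-c2nc3ccccc3s2)c(N[C@@H]2C[C@H](CO)[C@@H](O)[C@H]2O)n1` gives 12000 nM, which is a 3.0-fold higher number from compound 1 to compound 2 (0.48 log units; beyond the scatter). For compound 3 `Cc1nc(NCCNS(C)(=O)=O)nc(N[C@@H]2C[C@H](CO)[C@@H](O)[C@H]2O)c1-c1nc2ccccc2s1` this assay reports only a limit, > 25000 nM. Compound 3 therefore stands at the most tolerated end of the three due to the limit of > 25000 nM in this assay, at which 1 of the 3 values shown sits, and the steps reaching it, an at least 6.2-fold higher number from compound 1 to compound 3 (0.79 log units; beyond the scatter) and an at least 2.0-fold higher number from compound 2 to compound 3 (0.31 log units; beyond the scatter), are both beyond the scatter.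

Compound 4 `Cc1nc(NCc2ccccn2)nc(N[C@@H]2C[C@H](CO)[C@@H](O)[C@H]2O)c1-c1nc2ccccc2s1` differs from compound 3 by pyridin-2-yl in place of (methanesulfonamido)methyl on a saturated chain carbon bound to a nitrogen on an aromatic ring. Going by the values given here, no measured step covers this change; the measured steps show only that groups placed on that ring nitrogen raised the tolerated amount. Compound 4 is expected to give about 12000 nM, somewhere between 4000 nM and 30000 nM. That estimate means an at least 2.0-fold lower number from compound 3 to compound 4 (0.31 log units; beyond the scatter).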

Compound 4, half-maximal cytotoxic concentration: 13000 nM
The estimate for compound 4 lay 1.1-fold (0.03 log units) below the measured number; measured number inside the range.
By their numbers in this assay, from the lowest: compound 1; then compounds 2 and 4 (each within the scatter of the next). At a limit, above all of these: compound 3.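

In this assay, (pyridin-2-yl)methyl on the nitrogen on the aromatic ring also gives a rise, a 3.3-fold higher number from compound 1 to compound 4 (0.51 log units; beyond the scatter), so the rise is not confined to the open chains of compound 2 and compound 3. Swapping the ethoxycarbonyl chain for this ring-bearing group changes nothing that can be told apart, a 1.1-fold higher number from compound 2 to compound 4 (0.03 log units; within the scatter). The comparison with the methanesulfonamido chain reads an at least 1.9-fold lower number from compound 3 to compound 4 (0.28 log units; that floor lies within the scatter), and it rests on a limit: the limit of > 25000 nM in this assay, at which 1 of the 4 values shown sits.

From the compounds shown here alone, how far past its limit compound 3 really lies stays open. So does what an amine, a carboxylic acid or a longer chain ending in pyridin-2-yl would give at this place.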